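An Acetyl Group on the Amine Nitrogen of Compound 3

A few compounds are considered here, and "the series" means these few. Any claim that something is new, unique, unknown or untested is made for them only; others in the source may bear on it.

In a functional assay on HEp-2 cells (Homo sapiens) for cytotoxicity, read by MTT assay, with a stated time of 24 h (a higher number here means a weaker inhibitor, a lower number a stronger inhibitor), compound 1 `COc1cc(C)cc2c1C(=O)C=C(c1c(C)cc3c(c1OC)C(=O)C(Nc1ccc(Cl)cc1)=CC3=O)C2=O` gives 650 nM and compound 2 `COc1cc(C)cc2c1C(=O)C=C(c1c(C)cc3c(c1OC)C(=O)C(Nc1ccc4ccccc4c1)=CC3=O)C2=O` gives 2040 nM while compound 3 `CCOC(=O)CNC1=CC(=O)c2cc(C)c(C3=CC(=O)c4c(OC)cc(C)cc4C3=O)c(OC)c2C1=O` gives 860 nM on the same read-out. Two measured steps fix the standing of compound 3: there is a 1.3-fold higher number from compound 1 to compound 3 (0.12 log units; within the scatter) and, on the other side, a 2.4-fold lower number from compound 2 to compound 3 (0.38 log units; beyond the scatter) in this assay as well. Compound 4 `COc1cc(C)cc2c1C(=O)C=C(c1c(C)cc3c(c1OC)C(=O)C(NC(C)=O)=CC3=O)C2=O` has acetyl in place of (ethoxycarbonyl)methyl on an amine nitrogen and so turns the ((ethoxycarbonyl)methyl)amino group into acetamido. The largest step among the measured groups on that nitrogen is a 3.1-fold higher number from compound 1 to compound 2 (0.50 log units; beyond the scatter) and none of these steps involves acetyl. In this assay a step within the scatter is therefore expected, with no firm direction, though a modest one cannot be excluded. Compound 4 is estimated at 900 nM with 400 nM to 2100 nM as the expected range. In size this estimate means an expected 1.0-fold higher number from compound 3 to compound 4 (0.02 log units; within the scatter) for the change.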

Compound 4, half-maximal inhibitory concentration: 920 nM
For compound 4 the middle estimate is 1.0-fold (0.01 log units) below the measured one; the range from low to high includes it.
By their numbers in this assay, from the lowest: compounds 1, 3 and 4 (each within the scatter of the next); then compound 2.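

In this assay, the change to acetamido puts an amide on this nitrogen for the first time among the compounds shown, yet it gives a 1.1-fold higher number from compound 3 to compound 4 (0.03 log units; within the scatter) and a 1.4-fold higher number from compound 1 to compound 4 (0.15 log units; within the scatter), so compounds 1, 3 and 4 cannot be told apart despite carrying an aryl, an ester-bearing chain and an acetyl group. Among the compounds shown here, compound 2 stays apart from this group, with a 2.2-fold lower number from compound 2 to compound 4 (0.35 log units; beyond the scatter), which leaves naphthalen-2-yl as the only one of the four groups whose number stands clearly away from the others. Nothing available explains these results.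

The compounds shown leave open whether the unsubstituted amine, a carboxylic acid in place of the ethyl ester, or a longer acyl chain such as butanoyl would stay with compounds 1, 3 and 4. They also leave open whether benzoyl on this nitrogen would instead move towards compound 2.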